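The compounds below may be only part of what the source reports. "The series", "measured", "known", "first", "only" and "open" are said of these compounds alone.

Compound 1 `FC(F)(F)c1cccc(-c2nc3cnc(Nc4ccccn4)cc3[nH]2)c1` is one of three compounds of the series with numbers in a physicochemical assay for solubility, using the shake flask method, measured as kinetic solubility, with a stated time of 20 h, at pH 2; a higher number here means a more soluble compound, a lower number a less soluble compound; compound 1 gives 21000 nM, the lowest of the two plain numbers shown. Its nearest neighbour is compound 3 `FC(F)(F)c1cccc(-c2nc3cnc(Nc4cnccn4)cc3[nH]2)c1`, which gives 155000 nM, reached by a 7.4-fold higher number from compound 1 to compound 3 (0.87 log units; beyond the scatter). Compound 2 `COc1ccnc(Nc2cc3[nH]c(-c4cccc(C(F)(F)F)c4)nc3cn2)c1` gives only a limit in this assay, < 5000 nM, so the limit of < 5000 nM in this assay, at which 1 of the 3 values shown sits, applies to it. The move an at least 4.2-fold lower number from compound 1 to compound 2 (0.62 log units; beyond the scatter) is thus at least modest downward, and an at least 31-fold higher number from compound 2 to compound 3 (1.49 log units; beyond the scatter) is at least large upward.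

Compound 4 `CN1CCN(c2ccc(Nc3cc4[nH]c(-c5cccc(C(F)(F)F)c5)nc4cn3)nc2)CC1` differs from compound 1 in one place: 4-methylpiperazin-1-yl in place of hydrogen on an aromatic carbon. Within the data shown here, only the step from compound 1 to compound 2 is of the same kind, a substituent replacing hydrogen on an aromatic carbon, and it went down, an at least 4.2-fold lower number from compound 1 to compound 2 (0.62 log units; beyond the scatter). The group entering in compound 4 is, however, a larger non-aromatic ring with two hetero atoms rather than a methoxy, so that step is a weak guide; a step beyond the scatter is expected, and upward is taken as more likely. For compound 4 the expected number in this assay is 100000 nM, within 20000 nM to 500000 nM, a step of a 4.8-fold higher number from compound 1 to compound 4 (0.68 log units; beyond the scatter).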

Compound 4, solubility: 190000 nM
Estimate against measurement, compound 4: 1.9-fold (0.28 log units) below, and the stated range covers the measured number.
By their numbers in this assay, from the lowest: compound 1; then compounds 3 and 4 (each within the scatter of the next). At a limit, below all of these: compound 2.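

In this assay, 4-methylpiperazin-1-yl on an aromatic carbon of the six-membered aromatic ring with 1 nitrogen, two atoms from the ring nitrogen and para to a large group, gives a 9.0-fold higher number from compound 1 to compound 4 (0.96 log units; beyond the scatter). This is the first upward step among the compounds shown in which a group replaces hydrogen on an aromatic carbon, and it runs against the only other such step, an at least 4.2-fold lower number from compound 1 to compound 2 (0.62 log units; beyond the scatter), so this kind of change has no single direction across compounds 2 and 4. The lower end of that comparison is a limit and not a number: the limit of < 5000 nM in this assay, at which 1 of the 4 values shown sits.

With one group at this place, the step cannot be divided between the non-aromatic ring, its second nitrogen and its methyl. Morpholin-4-yl, piperidin-1-yl or a dimethylamino group at the same place would separate these parts.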